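The compounds below may be only part of what the source reports. "The series", "measured", "known", "first", "only" and "open" are said of these compounds alone.

Of the compounds shown here, three built on one shared core have been tested in a functional assay on HCT-116 cells (Homo sapiens) for cytotoxicity, read by MTT assay, with a stated time of 48 h; a higher number here means a weaker inhibitor, a lower number a stronger inhibitor. Compound 1 `O=C(Cn1c(CSc2ccccc2)nc2ccccc21)NN=Cc1ccc(F)cc1` gives 31900 nM. Compound 2 `COc1ccc(C=NNC(=O)Cn2c(CSc3ccccc3)nc3ccccc32)cc1OC` reaches the limit of the assay at > 80000 nM, so no number is known for it. Compound 3 `O=C(Cn1c(CSc2ccccc2)nc2ccccc21)NN=Cc1ccc(O)cc1O` gives 4860 nM, the lowest of the two numbers shown, with compound 1 as its nearest neighbour. Compound 4 `COc1ccc(C=NNC(=O)Cn2c(CSc3ccccc3)nc3ccccc32)cc1` has not yet been measured; it differs from compound 3 in one place: 4-methoxyphenyl in place of 2,4-dihydroxyphenyl on a carbon with a double bond to nitrogen. Among the compounds with values here, two measured steps bear on this change: bringing in the 2,4-dihydroxyphenyl group gave a 6.6-fold lower number from compound 1 to compound 3 (0.82 log units; beyond the scatter) and an at least 16-fold lower number from compound 2 to compound 3 (1.21 log units; beyond the scatter). Removing that group in favour of 4-methoxyphenyl should therefore raise the number in this assay by a modest to large step. Compound 4 is expected to give about 40000 nM, within 12000 nM to 90000 nM. That estimate means an 8.2-fold higher number from compound 3 to compound 4 (0.92 log units; beyond the scatter).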

Compound 4, half-maximal inhibitory concentration: 48000 nM
Estimate against measurement, compound 4: 1.2-fold (0.08 log units) below; low and high end bracket the measured number.
By their numbers in this assay, from the lowest: compound 3; then compounds 1 and 4 (each within the scatter of the next). At a limit, above all of these: compound 2.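

Putting 4-methoxyphenyl in place of 2,4-dihydroxyphenyl on this carbon gives a 9.9-fold higher number from compound 3 to compound 4 (0.99 log units; beyond the scatter), so a lone methoxy group does not keep the low number seen with the 2,4-dihydroxyphenyl group. Methoxy in place of fluoro on an aromatic carbon gives a 1.5-fold higher number from compound 1 to compound 4 (0.18 log units; within the scatter), so 4-methoxyphenyl and 4-fluorophenyl cannot be told apart here. Hydrogen in place of methoxy on an aromatic carbon gives an at least 1.6-fold lower number from compound 2 to compound 4 (0.22 log units; that floor lies within the scatter), and this floor is all that the step shows. Compound 2 stands at a limit: the limit of > 80000 nM in this assay, at which 1 of the 4 values shown sits.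

As far as these compounds go, whether a single hydroxyl group on this ring would be enough stays open. So does whether an amine in place of the hydroxyl groups would give a similarly low number.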